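The source may hold more compounds than are shown below. What is called first, only, known or untested is meant among the compounds shown, and "the series" means these compounds.

In an ADME assay on THP-1 cells (Homo sapiens) for cytotoxicity, read by flow cytometry and propidium iodide staining, with a stated time of 72 h (on this read-out lower numbers stand for stronger inhibition and higher numbers for weaker inhibition), three compounds sharing a core have been read so far. Compound 1, `COc1c(-c2cccc(F)c2)oc2ccc(NC(C)=O)cc2c1=O`, gives > 125000 nM, which is a limit of the assay and not a number. Compound 2, `COc1c(-c2ccccc2)oc2ccc(N)cc2c1=O`, gives a measured number, 74000 nM. Compound 3, `COc1c(-c2ccccc2F)oc2ccc(N)cc2c1=O`, gives > 125000 nM, again only a limit. Compound 3 therefore has no number of its own and stands at the limit of > 125000 nM in this assay, at which 2 of the 3 values shown sit.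

Compound 4, `COc1c(-c2cccc(F)c2)oc2ccc(N)cc2c1=O`, has not yet been measured. It has the same atoms as compound 3, joined differently: 3-fluorophenyl in place of 2-fluorophenyl on an aromatic carbon. For the measured compounds named here, one measured step bears on this change, fluoro in place of hydrogen on an aromatic carbon, and it is an at least 1.6-fold higher number from compound 2 to compound 3 (0.22 log units; that floor lies within the scatter). That step is only a floor and does not compare the two fluorophenyl groups, so it sets no size for the move. No step beyond the scatter is expected in this assay, in either direction. The expected change is modest, and the estimated step is an at least 1.1-fold lower number from compound 3 to compound 4 (0.05 log units; that floor lies within the scatter). The new result may well also be reported only as a limit. Compound 4 is expected at about 110000 nM, with an estimated range from 55000 nM to 220000 nM.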

Compound 4, half-maximal inhibitory concentration: 34000 nM
Compound 4: the middle estimate sits 3.2-fold (0.51 log units) above what was measured; the whole stated range lies above it.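

In this assay, 3-fluorophenyl in place of 2-fluorophenyl on an aromatic carbon gives an at least 3.6-fold lower number from compound 3 to compound 4 (0.56 log units; beyond the scatter), which shows that the reading at this position depends on where the fluoro group sits on the phenyl ring; this size is only a floor, since the 2-fluorophenyl compound is held at a limit. Fluoro in place of hydrogen now gives a 2.2-fold lower number from compound 2 to compound 4 (0.34 log units; beyond the scatter), the first step of this kind that lies beyond the scatter, whereas the earlier floor for the 2-fluorophenyl group stayed within it. With 3-fluorophenyl kept in place, hydrogen in place of acetyl on the nitrogen gives an at least 3.6-fold lower number from compound 1 to compound 4 (0.56 log units; beyond the scatter), again a floor, and the limits leave the full size of both floors unknown: the limit of > 125000 nM in this assay, at which 2 of the 4 values shown sit.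

The compounds shown leave open how far the true gap between the two fluorophenyl isomers extends, and whether a 3-chlorophenyl or 3-methylphenyl group would read like 3-fluorophenyl. They also leave open whether a methyl group or a longer acyl chain on the nitrogen would read like the acetyl group or like the free amine.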